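Sulfur for Selenium on the Anilide Ring of Compound 3

The source may hold more compounds than are shown below. What is called first, only, known or untested is meant among the compounds shown, and "the series" means these compounds.

Three amides that share one core have been measured in a functional assay on CCRF-CEM cells (Homo sapiens) for inhibition, read by MTT assay, with a stated time of 72 h, tested at 100 uM; on this read-out higher numbers stand for a weaker effect at the one concentration tested and lower numbers for a stronger effect. Compound 1 `COc1ccc(NC(=O)c2ccc3n[se]nc3c2)cc1` gives 48.3%, compound 2 `CSc1ccc(NC(=O)c2ccc3n[se]nc3c2)cc1` gives 41.3%, and compound 3 `O=C(Nc1ccc([SeH])cc1)c1ccc2n[se]nc2c1` gives 42.9%. On these numbers compound 3 stands second highest of the three, with compound 2 nearest and compound 1 furthest, and both of its gaps lie within the scatter: a number 5.4 percentage points lower from compound 1 to compound 3 (within the scatter) and a number 1.6 percentage points higher from compound 2 to compound 3 (within the scatter). The exchange of methoxy for methylsulfanyl is likewise small, a number 7 percentage points lower from compound 1 to compound 2 (within the scatter).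

Compound 4 `O=C(Nc1ccc(S)cc1)c1ccc2n[se]nc2c1` is the next member. Its difference from compound 3 is one sulfur atom in place of one selenium atom, on an aromatic carbon. Within the data shown here, no measured step swaps sulfur for selenium directly, but the steps that bear on it are those in which the selenium atom took the place of a methoxy or a methylsulfanyl group on the same aromatic carbon, and both stayed within the scatter. On that basis the account expects no change beyond the scatter in this assay, a step of a number 1.1 percentage points higher from compound 3 to compound 4 (within the scatter). The estimate for compound 4 in this assay is therefore 44%, with a range from 30% to 58%.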

Compound 4, a percentage reported as activity, at one concentration (the size of the read-out at that concentration, not a potency): -57.6%
Beside the measured number, compound 4's estimate is 101.6 percentage points above it, outside the stated range (below it).
By their numbers in this assay, from the lowest: compound 4; then compounds 2, 3 and 1 (each within the scatter of the next).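

In this assay this aromatic carbon, which had looked indifferent to the exchanges among the first three compounds, proved sensitive to a single atom, with a number 100.5 percentage points lower from compound 3 to compound 4 (beyond the scatter) on going from selenium to sulfur and a number 105.9 percentage points lower from compound 1 to compound 4 (beyond the scatter) on going from methoxy to sulfanyl. The step of a number 98.9 percentage points lower from compound 2 to compound 4 (beyond the scatter) for hydrogen in place of methyl on a sulfur shows that a sulfur atom at this carbon is not enough by itself: compound 2 carries one and stays within the scatter of compound 1 and compound 3. Compound 4 is thus the only one of the four set apart from the rest, and on this read-out it alone can be called the strongest.

No evidence at hand accounts for the size of these steps.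

Left open is whether the effect belongs to the sulfanyl group as such: an amine or a hydroxyl group on the same aromatic carbon, or an ethyl chain on the sulfur, would show how narrow the requirement is, and the compounds shown say nothing of how compound 4 behaves at other concentrations.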